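Two Cytotoxicity Readings and a Hybrid Analogue

This account rests on a few compounds, and the source may have more. Where it says the series, first, only, none or still open, it means among the compounds named here.

Compound 1 `COc1cccc(Oc2ccc3c(NCCCNCc4cccc(OC)c4O)ccnc3c2)c1` and compound 2 `COc1ccc(F)cc1CNCCCNc1ccnc2cc(-c3ccc(C(F)(F)F)cc3)ccc12` differ in more than one place, so only their two numbers can be compared. In an ADME assay on HepG2 cells (Homo sapiens) for cytotoxicity, read by luminescence, CellTiter-Glo and ATP content, with a stated time of 72 h (a lower number here means that less compound is needed, a higher number that more compound is needed for the effect), compound 1 gives 5300 nM. In this assay compound 2 gives 5190 nM, a number that stands alongside that of compound 1 within the usual scatter, so neither can be set apart from the other.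

Compound 3 `COc1cccc(CNCCCNc2ccnc3cc(-c4ccc(C(F)(F)F)cc4)ccc23)c1O` keeps the core of compound 2 and changes only the side chain: 2-hydroxy-3-methoxyphenyl in place of 5-fluoro-2-methoxyphenyl on a saturated chain carbon bound to an amine nitrogen. Among the measured compounds shown here, the group that enters is the one already carried by compound 1. For the measured compounds named here, no step between measured compounds is known here, and the two measured compounds agree with each other, which leaves nothing pointing to a change in either direction.

The expected outcome is therefore a step from compound 2 to compound 3 of a 1.0-fold higher number from compound 2 to compound 3 (0.00 log units; within the scatter) in this assay, none beyond the scatter. The estimate for compound 3 in this assay is 5200 nM, with a range from 2400 nM to 11000 nM.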

Compound 3, half-maximal effective concentration: 2210 nM
Estimate against measurement, compound 3: 2.4-fold (0.37 log units) above, outside the stated range (below it).
By their numbers in this assay, from the lowest: compound 3; then compounds 2 and 1 (each within the scatter of the next).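

In this assay the change on a saturated chain carbon bound to an amine nitrogen registers: 2-hydroxy-3-methoxyphenyl in place of 5-fluoro-2-methoxyphenyl gives a 2.3-fold lower number from compound 2 to compound 3 (0.37 log units; beyond the scatter) and so less compound is needed for the effect. The change on an aromatic carbon, 4-(trifluoromethyl)phenyl in place of 3-methoxyphenoxy, gives a 2.4-fold lower number from compound 1 to compound 3 (0.38 log units; beyond the scatter) and so compound 3, which carries both entering groups, stands apart from compound 1 and compound 2, which could not be told apart from each other. Nothing available explains why either change moves the number.

The swap on the chain alters the hydroxy, methoxy and fluorine substituents together, so it remains open which of them accounts for the step. Also open, as far as these compounds go, is how a longer chain, or an amine or a carboxylic acid in place of the 2-hydroxy-3-methoxyphenyl group, would read in this assay.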